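Solubility outlook for the nitro analogue of compound 1

The source may hold more compounds than are shown below. What is called first, only, known or untested is meant among the compounds shown, and "the series" means these compounds.

Compound 1 `O=C(CN1CCN(c2cc3c(cc2F)c(=O)c(C(=O)O)cn3C2CC2)CC1)Nc1ccc(C(=O)/C=C/c2ccccc2)cc1` stands second highest of the three numbers in a physicochemical assay for solubility, at pH 6.9 (on this read-out higher numbers stand for higher solubility and lower numbers for lower solubility), where compound 1 gives 2.73 ug/mL. Compound 2 `O=C(CN1CCN(c2cc3c(cc2F)c(=O)c(C(=O)O)cn3C2CC2)CC1)Nc1ccc(C(=O)/C=C/c2cccc(Cl)c2)cc1` gives 34.4 ug/mL in this assay, and compound 3 `COc1ccc(/C=C/C(=O)c2ccc(NC(=O)CN3CCN(c4cc5c(cc4F)c(=O)c(C(=O)O)cn5C4CC4)CC3)cc2)cc1OC` gives 0.75 ug/mL. The step of a 13-fold higher number from compound 1 to compound 2 (1.10 log units; beyond the scatter) is large and upward, the step of a 3.6-fold lower number from compound 1 to compound 3 (0.56 log units; beyond the scatter) is modest and downward, and a 46-fold lower number from compound 2 to compound 3 (1.66 log units; beyond the scatter) separates the two substituted analogues. The unmeasured compound 4 `O=C(CN1CCN(c2cc3c(cc2F)c(=O)c(C(=O)O)cn3C2CC2)CC1)Nc1ccc(C(=O)/C=C/c2cccc([N+](=O)[O-])c2)cc1` differs from compound 1 by nitro in place of hydrogen on an aromatic carbon, the group sitting on an aromatic carbon of a six-membered aromatic ring of carbon only, meta to a large group. The step from compound 1 to compound 2 bears most directly on this change, since it also enters a single group on the same ring, whereas the step to compound 3 enters two groups and goes the other way. Because a 13-fold higher number from compound 1 to compound 2 (1.10 log units; beyond the scatter) is large while a 3.6-fold lower number from compound 1 to compound 3 (0.56 log units; beyond the scatter) is modest, an upward step in this assay is expected for compound 4, though with wide uncertainty. For compound 4 the expected step is a 2.9-fold higher number from compound 1 to compound 4 (0.47 log units; beyond the scatter). Compound 4 is estimated at 8 ug/mL, within a range from 1.5 ug/mL to 40 ug/mL.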

Compound 4, solubility: 30.7 ug/mL
Compound 4: middle estimate off by 3.8-fold (0.58 log units), on the low side; the range from low to high includes it.
By their numbers in this assay, from the lowest: compound 3; then compound 1; then compounds 4 and 2 (each within the scatter of the next).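

In this assay, for the compounds shown here, the change of nitro for hydrogen gives an 11-fold higher number from compound 1 to compound 4 (1.05 log units; beyond the scatter) on the same aromatic carbon, so chloro is no longer the only single group with a large upward step at this place. Nitro in place of chloro gives a 1.1-fold lower number from compound 2 to compound 4 (0.05 log units; within the scatter) and so does not separate the two groups, while a 41-fold higher number from compound 3 to compound 4 (1.61 log units; beyond the scatter) leaves the 3,4-dimethoxyphenyl of compound 3 as the case against any general rise with substitution on this ring. No measurement shown bears on why compound 2 and compound 4 read alike.

Going by these compounds, it remains open whether an amine or a carboxylic acid on this aromatic carbon would read like compound 2 and compound 4 or like compound 3. A single methoxy group at this place would show whether the low reading of compound 3 goes with one such group or needs both.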